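The source may report more compounds than this note shows. Statements on the series, on what has been measured and on what is new or still open speak of the compounds shown alone.

Three members of the series have been run in a functional assay on KYSE-70 cells for antiproliferative activity against KYSE-70 cell line (Homo sapiens), read by MTT assay, with a stated time of 72 h (on this read-out higher numbers stand for weaker inhibition and lower numbers for stronger inhibition), and none returned a number. Compound 1 `COc1ccc(NC(=O)c2cc(=O)[nH]c3cc(Br)ccc23)cc1` sits at the limit of the assay, > 20000 nM. Compound 2 `O=C(Nc1cccc(OC(F)(F)F)c1)c1cc(=O)[nH]c2cc(Br)ccc12` likewise gives only the limit, > 20000 nM. Compound 3 `CC(C)(C)c1ccc(-c2ccc3c(C(=O)Nc4cccc(F)c4)cc(=O)[nH]c3c2)cc1`, which carries the 4-(tert-butyl)phenyl group on the shared core, also stands at the limit, > 20000 nM. Compound 3 therefore stands exactly where the other two stand, namely at the limit of > 20000 nM in this assay, at which 3 of the 3 values shown sit, and with no measured step between any pair of these compounds nothing in the numbers separates one from another.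

The next compound, compound 4 `O=C(Nc1cccc(F)c1)c1cc(=O)[nH]c2cc(-c3ccncc3)ccc12`, alters one place on compound 3: pyridin-4-yl in place of 4-(tert-butyl)phenyl on an aromatic carbon. A six-membered aromatic ring of carbon only leaves and a six-membered aromatic ring with 1 hetero atom enters, at an aromatic carbon of the shared core.

Among the compounds with values here, since no measured pair gives a step, no direction can be read from the data; the step from compound 3 to compound 4 is expected to be modest, leaning toward stronger inhibition, with low confidence. The expected step is an at least 1.6-fold lower number from compound 3 to compound 4 (0.22 log units; that floor lies within the scatter). For compound 4 the estimate in this assay is 12000 nM, within a range from 2000 nM to 40000 nM, and a sizeable chance remains that only the limit is reported again.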

Compound 4, half-maximal inhibitory concentration: > 20000 nM
Compound 4: no number, only a limit (the forecaster's own chance of this, stated with the estimate: 50%); middle value at least 1.6-fold (0.22 log units) from the limit.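

Compound 3 and compound 4 both return only a limit in this assay, so the step for pyridin-4-yl in place of 4-(tert-butyl)phenyl cannot be read, and the series stays unresolved: the limit of > 20000 nM in this assay, at which 4 of the 4 values shown sit.

The compounds shown leave open which change on the shared core, if any, would give a measurable number in this assay.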